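Notes on the step from compound 2 to compound 3

A few compounds are considered here, and "the series" means these few. Any claim that something is new, unique, unknown or untested is made for them only; others in the source may bear on it.

Measured so far:
compound 1 `COc1ccc(-c2cn3ccnc3c(-c3ccc4ncn(C5CCCCC5)c4c3)n2)cc1`: 91.3%
compound 2 `Fc1ccc(-c2cn3ccnc3c(-c3ccc4ncn(C5CCCCC5)c4c3)n2)cc1`: 18%

In a functional assay on HCT-116 cells (Homo sapiens) for inhibition, read by sulforhodamine B assay, with a stated time of 48 h, tested at 10 uM (a lower number here means less inhibition, a higher number more inhibition at the concentration tested (going by the name of the read-out)), compound 1 gives 91.3% and compound 2 gives 18%. Among the measured compounds shown here, compound 2 stands lowest of the two numbers; the only known step, a number 73.3 percentage points lower from compound 1 to compound 2 (beyond the scatter), is large and beyond the scatter, and it alters the group on the same aromatic carbon that changes now. Compound 3 `c1cn2cc(-c3ccsc3)nc(-c3ccc4ncn(C5CCCCC5)c4c3)c2n1` is not yet measured in this assay. Its difference from compound 2: thiophen-3-yl in place of 4-fluorophenyl on an aromatic carbon. For the measured compounds named here, the one measured step shows that the group at this place can move the read-out strongly, but no measured compound carries thiophen-3-yl, so the direction rests only on compound 2 sitting at the low end. A moderate upward step is expected, a number 17 percentage points higher from compound 2 to compound 3 (beyond the scatter), with wide uncertainty. Compound 3 is therefore estimated at 35%, expected range 10% to 70%.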

Compound 3, a percentage reported as inhibition, at one concentration (the size of the read-out at that concentration, not a potency): 13.4%
Estimate against measurement, compound 3: 21.6 percentage points above; measured number inside the range.
By their numbers in this assay, from the lowest: compounds 3 and 2 (each within the scatter of the next); then compound 1.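

In this assay, the change from 4-fluorophenyl to thiophen-3-yl gives a number 4.6 percentage points lower from compound 2 to compound 3 (within the scatter), so a five-membered sulfur-containing ring and a six-membered fluorinated carbon ring cannot be told apart at this position. Replacing 4-methoxyphenyl with thiophen-3-yl gives a number 77.9 percentage points lower from compound 1 to compound 3 (beyond the scatter), a large step like a number 73.3 percentage points lower from compound 1 to compound 2 (beyond the scatter), so among these three compounds only the 4-methoxyphenyl group gives a high number, and the earlier drop is not peculiar to 4-fluorophenyl. No measurement at hand explains this difference between the groups.

From the compounds shown here alone, it remains open whether the high number depends on the methoxy group itself or would also appear with another group on the phenyl ring, such as 4-ethoxyphenyl, 4-hydroxyphenyl or 4-aminophenyl. Readings at a single concentration also leave the potency of all three compounds open.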